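Replacing the 2,3-dihydroxypropyl group of compound 2

This account rests on a few compounds, and the source may have more. Where it says the series, first, only, none or still open, it means among the compounds named here.

In a toxicity assay on HEK-293T cells (Homo sapiens) for cytotoxicity, read by MTT assay, with a stated time of 72 h (a lower number here means a stronger inhibitor, a higher number a weaker inhibitor), compound 1 `CN(C)CCCCCn1c2c(c3ccccc31)C(=O)c1c[n+]([O-])c3ccccc3c1C2=O` gives 70 nM and compound 3 `O=C1c2c[n+]([O-])c3ccccc3c2C(=O)c2c1c1ccccc1n2CCCCN1CCNCC1` gives 760 nM as its value. Compound 2 `O=C1c2c[n+]([O-])c3ccccc3c2C(=O)c2c1c1ccccc1n2Cc1cn(C[C@H](O)CO)nn1` stands highest at 8880 nM with its steps to both others beyond the scatter, which makes it the weakest inhibitor of the three.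

Compound 4 `O=C1c2c[n+]([O-])c3ccccc3c2C(=O)c2c1c1ccccc1n2Cc1cn([C@H]2C[C@H](O)[C@@H](CO)O2)nn1` changes one group of compound 2 on an aromatic nitrogen of a five-membered aromatic ring (4-hydroxy-5-(hydroxymethyl)oxolan-2-yl in place of 2,3-dihydroxypropyl on an aromatic nitrogen). Going by the values given here, two measured steps bear on this only from a distance. One is a 130-fold higher number from compound 1 to compound 2 (2.10 log units; beyond the scatter) and the other is a 12-fold lower number from compound 2 to compound 3 (1.07 log units; beyond the scatter) and both are large, yet each swaps the whole chain on the core. Among the compounds with values here, compound 4 keeps the 1H-1,2,3-triazol-4-yl group of compound 2, and no measured pair changes only what sits on that group. A step of that size is therefore not expected, and the estimate is (a 1.1-fold lower number from compound 2 to compound 4 (0.05 log units; within the scatter)), with no direction beyond the scatter expected. Compound 4 is expected at 8000 nM (estimated range 2500 nM to 25000 nM).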

Compound 4, half-maximal inhibitory concentration: 3600 nM
For compound 4 the middle estimate is 2.2-fold (0.35 log units) above the measured one; the range from low to high includes it.
By their numbers in this assay, from the lowest: compound 1; then compound 3; then compound 4; then compound 2.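

Going by these compounds alone, until this result, every measured step swapped the whole chain on the core, so none showed whether the group on the aromatic nitrogen of the five-membered aromatic ring matters by itself. With the 1H-1,2,3-triazol-4-yl group kept, in this assay the 4-hydroxy-5-(hydroxymethyl)oxolan-2-yl group in place of 2,3-dihydroxypropyl gives a 2.5-fold lower number from compound 2 to compound 4 (0.39 log units; beyond the scatter), a modest step but one beyond the scatter, so this position does respond to a change made there alone. Nothing measured here accounts for the step.

The entering group brings a ring, an extra oxygen and more stereocentres all at once, and the compounds shown cannot separate these. Going by these compounds, how a carboxylic acid or an amine on this same aromatic nitrogen would read also remains open.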